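Ester Aryl Swap on a Nitroanilide Core: Compound 4

The source may hold more compounds than are shown below. What is called first, only, known or untested is meant among the compounds shown, and "the series" means these compounds.

Measured compounds:
Compound 1 `O=C(OC1(C(=O)Nc2ccc([N+](=O)[O-])cc2)CCCCC1)c1ccc(C(F)(F)F)cc1`, in a functional assay on MCF7 cells (Homo sapiens) for inhibition, read by MTT assay, with a stated time of 72 h (a higher number here means a weaker inhibitor, a lower number a stronger inhibitor), compound 1 gives 27.1 nM.
Compound 2 `O=C(OC1(C(=O)Nc2ccc([N+](=O)[O-])cc2)CCCCC1)c1ccc(Cl)cc1`, in this assay compound 2 gives 15 nM.
Compound 3 `COc1ccc(C(=O)OC2(C(=O)Nc3ccc([N+](=O)[O-])cc3)CCCCC2)cc1`, in this assay compound 3 gives 41.2 nM.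

Compound 2 has the lowest number of the three; the step that leads to it is a 1.8-fold lower number from compound 1 to compound 2 (0.26 log units; within the scatter), and the step that leads away from it is a 2.7-fold higher number from compound 2 to compound 3 (0.44 log units; beyond the scatter). Compound 4 `Cc1ccccc1C(=O)OC1(C(=O)Nc2ccc([N+](=O)[O-])cc2)CCCCC1` differs from compound 2 by 2-methylphenyl in place of 4-chlorophenyl on a carbonyl carbon. For the measured compounds named here, none of the measured steps makes this exact change; each of them only exchanges one group for another on the same aromatic carbon, and these steps were a 1.8-fold lower number from compound 1 to compound 2 (0.26 log units; within the scatter) and a 1.5-fold higher number from compound 1 to compound 3 (0.18 log units; within the scatter). Since compound 2 already holds the lowest number, a modest move to a higher number is expected, a 2.3-fold higher number from compound 2 to compound 4 (0.37 log units; beyond the scatter). Compound 4 is therefore estimated at 35 nM, between 12 nM and 100 nM.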

Compound 4, half-maximal inhibitory concentration: 516 nM
Compound 4: middle estimate off by 15-fold (1.17 log units), on the low side; the measured number lies above the stated range.
By their numbers in this assay, from the lowest: compounds 2, 1 and 3 (each within the scatter of the next, the first and the last beyond it); then compound 4.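

At the aryl group on the ester carbonyl, exchanges among 4-chlorophenyl, 4-(trifluoromethyl)phenyl and 4-methoxyphenyl had shifted the number in this assay only slightly or modestly, whereas 2-methylphenyl brings much larger steps: a 34-fold higher number from compound 2 to compound 4 (1.54 log units; beyond the scatter) and a 19-fold higher number from compound 1 to compound 4 (1.28 log units; beyond the scatter) and a 13-fold higher number from compound 3 to compound 4 (1.10 log units; beyond the scatter). For the compounds shown here, this position is therefore far less tolerant of change than the earlier compounds suggested, and all three steps point the same way. Nothing available here explains the shift.

Going by these compounds, whether the methyl group itself or its place on the ring carries the change remains open. An unsubstituted phenyl group or an aminophenyl group would bear on that question.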